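From Chloro to Methoxy on the Shared Core

A few compounds are considered here, and "the series" means these few. Any claim that something is new, unique, unknown or untested is made for them only; others in the source may bear on it.

In a functional assay on L1210 cells (Mus musculus) for inhibition (on this read-out higher numbers stand for weaker inhibition and lower numbers for stronger inhibition), compound 1 `C=C1[C@@H](O)[C@H](n2ccc(N)nc2=O)O[C@@H]1CO` gives 378000 nM as its number. Compound 2 `C=C1[C@H](n2cnc3c(Cl)nc(N)nc32)O[C@H](CO)[C@H]1O` stands lowest of the two at 10000 nM and so shows the stronger inhibition, with a gap to compound 1 that lies beyond the scatter. Within the data shown here, no two measured compounds differ in one place only, so no measured step speaks directly to the next change.

Compound 3 `C=C1[C@H](n2cnc3c(OC)nc(N)nc32)O[C@H](CO)[C@H]1O` has yet to be measured. It departs from compound 2 in one place: methoxy in place of chloro on an aromatic carbon on an aromatic carbon next to the ring nitrogen and meta to an amino group. With nothing measured on this exchange of methoxy for chloro, the expectation rests on judgement alone. In this assay a moderate step toward a higher number, meaning weaker inhibition, is expected, although a step within the scatter would not surprise. The expected move is a 3.0-fold higher number from compound 2 to compound 3 (0.48 log units; beyond the scatter) on this estimate. For compound 3 the estimated value is 30000 nM with an expected range from 8000 nM to 120000 nM around it.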

Compound 3, half-maximal inhibitory concentration: 10000 nM
Compound 3: middle estimate off by 3.0-fold (0.48 log units), on the high side, and the stated range covers the measured number.
By their numbers in this assay, from the lowest: compounds 2 and 3 (each within the scatter of the next); then compound 1.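

In this assay, methoxy in place of chloro on this aromatic carbon gives no change at the digits printed from compound 2 to compound 3 (within the scatter). Among these compounds, compound 1 and compound 2 differ in more than one place, so this pair gives the first reading that belongs to a single position. It shows that this position accepts methoxy, with 2 heavy atoms and 1 hydrogen-bond acceptor, in place of chloro, with 1 heavy atom and no hydrogen-bond acceptor, with no difference that stands out from the scatter. Nothing available explains why the two groups read alike.

As far as these compounds go, whether this match extends to other groups on the same carbon stays open, for instance ethoxy, a longer ether chain or dimethylamine. Among the compounds shown here, with only this one exchange, it also remains unclear whether either group matters here at all, a question that a plain hydrogen on this carbon would test.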